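Replacing an Ethyl With Bromo on the Amide Chain

This account rests on a few compounds, and the source may have more. Where it says the series, first, only, none or still open, it means among the compounds named here.

Measured compounds:
- compound 1, `CCC/C=C/C(=O)N(Cc1ccc(OC)c(O)c1)c1cc(OC)c(OC)c(OC)c1`: 70 nM
- compound 2, `C/C=C/C(=O)N(Cc1cc(OC)c(OC)c(OC)c1)c1ccc(OC)c(O)c1`: 6150 nM
- compound 3, `COc1ccc(CNc2cc(OC)c(OC)c(OC)c2)cc1F`: 39700 nM

In a functional assay on MGC-803 cells (Homo sapiens) for inhibition, read by MTT assay, with a stated time of 48 h (a lower number here means a stronger inhibitor, a higher number a weaker inhibitor), compound 1 gives the lowest number of the three measured compounds. Compound 2 lies well beyond the scatter from it, and compound 3 lies further still, so compound 1 is the strongest inhibitor shown here.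

Compound 4, `COc1ccc(CN(C(=O)/C=C/CBr)c2cc(OC)c(OC)c(OC)c2)cc1O`, keeps the core of compound 1 and differs from it in one place: bromo in place of ethyl on a saturated chain carbon bound to a double-bonded chain carbon. The pent-1-en-1-yl chain of compound 1 becomes a 3-bromoprop-1-en-1-yl chain in compound 4.

No pair of measured compounds differs by this kind of change, so its size is not known from the shown data. The expected step is a modest one, probably toward a higher number, and it may not exceed the scatter. Taking compound 1 as the starting point, the step of a 2.9-fold higher number from compound 1 to compound 4 (0.46 log units; beyond the scatter) is an estimate only. In this assay compound 4 is expected to give about 200 nM, between 40 nM and 1500 nM.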

Compound 4, half-maximal inhibitory concentration: 71 nM
Beside the measured number, compound 4's estimate is 2.8-fold (0.45 log units) above it, within the range that was stated.
By their numbers in this assay, from the lowest: compounds 1 and 4 (each within the scatter of the next); then compound 2; then compound 3.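

In this assay, the step of a 1.0-fold higher number from compound 1 to compound 4 (0.01 log units; within the scatter) leaves the two compounds within the usual scatter of each other, so their numbers cannot be told apart. Going by these compounds alone, none of the earlier compounds formed a pair differing in one place, which makes this the first direct reading of a change on the amide chain. On a saturated chain carbon bound to a double-bonded chain carbon, bromo and ethyl give matching numbers, but no supporting data explain this match.

The compounds shown leave open whether this match extends to other groups at the same place, such as chloro, an amine or a carboxylic acid. They also leave open how a longer chain carrying bromo at its end would read in this assay.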